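Working notes: dimethylamino on compound 1

The compounds below may be only part of what the source reports. "The series", "measured", "known", "first", "only" and "open" are said of these compounds alone.

Among the measured compounds shown here, in a functional assay on HeLa cells (Homo sapiens) for antiproliferative activity, with a stated time of 48 h (on this read-out lower numbers stand for stronger inhibition and higher numbers for weaker inhibition), compound 1 (`C=C(Br)C(=O)Nc1ccc(C(=O)/C=C/c2ccccc2)cc1`) gives 960 nM and compound 2 (`C=C(Br)C(=O)Nc1ccc(C(=O)/C=C/c2ccccc2OC)cc1`) gives 1300 nM so compound 1 has only one neighbour, and the two values lie within the scatter of each other. Compound 3 (`C=C(Br)C(=O)Nc1ccc(C(=O)/C=C/c2ccc(N(C)C)cc2)cc1`) carries dimethylamino in place of hydrogen on an aromatic carbon, para to a large group (dimethylamino in place of hydrogen on an aromatic carbon). For the measured compounds named here, the only measured step bearing on this involves a different group, methoxy, and is a 1.4-fold higher number from compound 1 to compound 2 (0.13 log units; within the scatter) so no step beyond the scatter is expected in this assay and no direction is favoured. The expected change is a 1.1-fold lower number from compound 1 to compound 3 (0.03 log units; within the scatter) as a working figure. For compound 3 the estimated value is 900 nM with an expected range from 320 nM to 2500 nM in this series.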

Compound 3, half-maximal inhibitory concentration: 610 nM
For compound 3 the middle estimate is 1.5-fold (0.17 log units) above the measured one; the range from low to high includes it.
By their numbers in this assay, from the lowest: compounds 3, 1 and 2 (each within the scatter of the next, the first and the last beyond it).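

In this assay, the aromatic carbon para to a large group accepts dimethylamino, with its 3 heavy atoms, in place of hydrogen (a 1.6-fold lower number from compound 1 to compound 3 (0.20 log units; within the scatter)). Among the compounds shown here, the earlier compounds showed only methoxy, on a different carbon of the same ring, so this is the first reading at this position, and the step stays within the scatter. No measurement bears on why the number sits where it does. As far as these compounds go, whether a carboxylic acid or a primary amine on this same aromatic carbon would give a step beyond the scatter remains open.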